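A few compounds are considered here, and "the series" means these few. Any claim that something is new, unique, unknown or untested is made for them only; others in the source may bear on it.

The series shares one core, varied only at the amine nitrogen in the ring. Compound 1 `CC(C)(C)OC(=O)N1CCC(CCCNc2ccc3c(c2)OCC3=O)CC1` is measured in a functional assay on CHO-K1 cells for agonist activity at Glucose-dependent insulinotropic receptor (Mus musculus), read by HTRF and cAMP accumulation, with a stated time of 30 min (a lower number here means a smaller maximal response, a higher number a larger maximal response), and gives 108%. Among the measured compounds shown here, compound 2 `COC(=O)c1cnc(N2CCC(CCCNc3ccc4c(c3)OCC4=O)CC2)nc1` gives in this assay 67%, so that the one measured step on this position, a number 41 percentage points lower from compound 1 to compound 2 (beyond the scatter), is a large one and lies beyond the scatter. Compound 3 `CC(C)c1noc(N2CCC(CCCNc3ccc4c(c3)OCC4=O)CC2)n1` carries a 3-isopropyl-1,2,4-oxadiazol-5-yl at the same place, but for compound 3 the entry in this assay reads "not determined" (no result reported), so it stands without a number of its own.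

Compound 4 `CC(C)c1nnc(N2CCC(CCCNc3ccc4c(c3)OCC4=O)CC2)o1` differs from compound 3 in one place: 5-isopropyl-1,3,4-oxadiazol-2-yl in place of 3-isopropyl-1,2,4-oxadiazol-5-yl on an amine nitrogen in a ring

For the measured compounds named here, no measured step bears directly on this change, since compound 3 has no value to step from; the only measured step at this position, a number 41 percentage points lower from compound 1 to compound 2 (beyond the scatter), concerns different groups. What can be said is that a heteroaryl group on this nitrogen is seen once, in compound 2, which in this assay gives 67%. On that basis alone, compound 4 is expected to show a maximal response in this assay of about 80%, estimated to fall between 50% and 110%.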

Compound 4, largest response reached (Emax), in percent of the reference or control that the assay uses: 88%
Beside the measured number, compound 4's estimate is 8 percentage points below it; the range from low to high includes it.
By their numbers in this assay, from the lowest: compound 2; then compound 4; then compound 1.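

With compound 4, a second heteroaryl group on the amine nitrogen in the ring has a value, and the two such groups do not read alike in this assay: the result is a number 21 percentage points higher from compound 2 to compound 4 (beyond the scatter) and, against the carbamate-bearing parent, a number 20 percentage points lower from compound 1 to compound 4 (beyond the scatter) and so the 5-isopropyl-1,3,4-oxadiazol-2-yl group places compound 4 at a level of its own, apart from both earlier compounds. The exchange of 3-isopropyl-1,2,4-oxadiazol-5-yl for 5-isopropyl-1,3,4-oxadiazol-2-yl, which keeps the same atoms joined differently, still cannot be read, as compound 3 has no number to compare with compound 4. Nothing at hand accounts for the differences among these groups at this position.

Open is what the isopropyl group itself contributes, as no methyl, cyclopropyl or longer chain stands in its place on the 1,3,4-oxadiazole among the compounds shown. Also open, as far as these compounds go, is how a simple acetyl group, a plain phenyl ring or a pyrimidine bearing a carboxylic acid instead of the methyl ester would read at this nitrogen.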